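Replacing the amino group: from compound 2 to compound 3

This account rests on a few compounds, and the source may have more. Where it says the series, first, only, none or still open, it means among the compounds named here.

compound 1 `CN(C)c1c(C#N)c2c(N)ncnc2n1C`: 259 nM
compound 2 `Cn1c(N)c(C#N)c2c(N)ncnc21`: 589 nM

Of the compounds shown here, two have been measured in an assay on isolated protein for binding affinity to Leucine-rich repeat serine/threonine-protein kinase 2 variant G2019S (Homo sapiens), read by TR-FRET and LanthaScreen, with a stated time of 2 h; on this read-out lower numbers stand for stronger inhibition and higher numbers for weaker inhibition. Compound 1 `CN(C)c1c(C#N)c2c(N)ncnc2n1C` gives 259 nM, while compound 2 `Cn1c(N)c(C#N)c2c(N)ncnc21` gives 589 nM and so stands at the higher of the two numbers. Among the measured compounds shown here, the single measured step, a 2.3-fold higher number from compound 1 to compound 2 (0.36 log units; beyond the scatter), shows a modest loss on moving from dimethylamino to amino. Compound 3 `Cn1c(-n2cccc2)c(C#N)c2c(N)ncnc21` differs from compound 2 by 1H-pyrrol-1-yl in place of amino on an aromatic carbon. For the measured compounds named here, no measured step covers a pyrrolyl group; the only step available shows the larger substituent binding more strongly, so a return toward the level of compound 1 is expected, with wide uncertainty. Compound 3 is therefore expected to show a 2.0-fold lower number from compound 2 to compound 3 (0.29 log units; within the scatter) in this assay. The estimate for compound 3 is 300 nM, between 80 nM and 1200 nM.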

Compound 3, inhibition constant: 1980 nM
Compound 3: middle estimate off by 6.6-fold (0.82 log units), on the low side; the measured number lies above the stated range.
By their numbers in this assay, from the lowest: compound 1; then compound 2; then compound 3.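

In this assay, 1H-pyrrol-1-yl on this aromatic carbon gives a 3.4-fold higher number from compound 2 to compound 3 (0.53 log units; beyond the scatter) and, set against dimethylamino, a 7.6-fold higher number from compound 1 to compound 3 (0.88 log units; beyond the scatter) so the larger group no longer gives the lower number, and group size alone does not order these three compounds. The change from amino also adds a five-membered aromatic ring and removes a hydrogen-bond donor, and these compounds cannot separate the two. Nothing available explains the loss. Open, on these data alone, is whether a saturated pyrrolidin-1-yl or a diethylamino group here would stay near compound 1 or fall toward compound 3.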